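Swapping the 4-(Dimethylamino)phenyl Group for 2,3-Dihydro-1H-indol-1-yl

A few compounds are considered here, and "the series" means these few. Any claim that something is new, unique, unknown or untested is made for them only; others in the source may bear on it.

For the measured compounds named here, compound 2 `Cc1occc1-c1nnc(SCC(=O)Nc2ccc(N(C)C)cc2)n1Cc1ccco1` is the only member of this small set with a numerical result: in a functional assay on CHO cells for antagonist activity at Orexin/Hypocretin receptor type 1 (Homo sapiens), read by FLIPR and calcium flux (on this read-out higher numbers stand for weaker inhibition and lower numbers for stronger inhibition), compound 2 gives 794 nM. Compound 1 `Cc1ccc(NC(=O)CSc2nnc(-c3ccoc3C)n2Cc2ccco2)cc1` reaches only a limit of the assay, since in this assay compound 1 gives > 15800 nM. Going by the values given here, the single measured step, an at least 19-fold lower number from compound 1 to compound 2 (1.29 log units; beyond the scatter), concerns the same end of the molecule that is now altered; its stated size rests on (the limit of > 15800 nM in this assay, at which 1 of the 2 values shown sits). Compound 3 `Cc1occc1-c1nnc(SCC(=O)NN2CCc3ccccc32)n1Cc1ccco1` differs from compound 2 by 2,3-dihydro-1H-indol-1-yl in place of 4-(dimethylamino)phenyl on an amide-type nitrogen. The 4-(dimethylamino)phenyl group that departs is the very group whose arrival in an at least 19-fold lower number from compound 1 to compound 2 (1.29 log units; beyond the scatter) accompanied the large gain, and the amide-type nitrogen now carries a ring in place of its hydrogen. On that basis the step is expected to run toward weaker inhibition, estimated as a 6.3-fold higher number from compound 2 to compound 3 (0.80 log units; beyond the scatter). For compound 3 the expected value in this assay is 5000 nM, with a range from 1000 nM to 30000 nM, and a fair chance that the assay reports only a limit.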

Compound 3, inhibition constant: > 15800 nM
Compound 3 gave a limit, no number (the forecaster's own chance of this, stated with the estimate: 40%); middle value at least 3.1-fold (0.49 log units) from the limit.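

Replacing 4-(dimethylamino)phenyl with 2,3-dihydro-1H-indol-1-yl on the amide-type nitrogen gives an at least 19-fold higher number from compound 2 to compound 3 (1.29 log units; beyond the scatter) in this assay, although the two groups have the same heavy atoms and the same counts of hydrogen-bond donors and acceptors, so these counts alone do not preserve the read-out at this position. Compound 3 gives > 15800 nM, which is a limit of the assay and not a number. Compound 2 therefore remains the only one of the three compounds with a numerical result, the step from compound 1 to compound 3 cannot be read, and the step out of compound 2 has only a bounded size: the limit of > 15800 nM in this assay, at which 2 of the 3 values shown sit.

The compounds shown leave open whether the numerical result of compound 2 depends on the dimethylamino group itself or on the way the aromatic ring is joined to the amide-type nitrogen. A plain phenyl group, or a 4-methoxyphenyl or 4-(diethylamino)phenyl group, on that nitrogen would bear on this question.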